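The source may report more compounds than this note shows. Statements on the series, on what has been measured and on what is new or still open speak of the compounds shown alone.

Measured so far:
- compound 1, `C[C@@H]1CCCN1c1c(C#N)c2c(N)ncnc2n1C`: 0.7 nM
- compound 2, `C[C@@H]1CCCN1c1c(C#N)c2c(N)nc(N)nc2n1C`: 13 nM

Both compounds were tested in an assay on isolated protein for binding affinity to Leucine-rich repeat serine/threonine-protein kinase 2 variant G2019S (Homo sapiens), read by TR-FRET and LanthaScreen, with a stated time of 2 h; on this read-out lower numbers stand for stronger inhibition and higher numbers for weaker inhibition. Compound 2 carries an amino group where compound 1 has only a hydrogen, and that single change gave a 19-fold higher number from compound 1 to compound 2 (1.27 log units; beyond the scatter). Within this small set compound 2 therefore stands at the higher end: its number is the highest of the two, and the only neighbour, compound 1, sits a long way below it.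

Compound 3, `Cc1nn(C)cc1Nc1nc(N)c2c(C#N)c(N3CCC[C@H]3C)n(C)c2n1`, grows out of compound 2 at exactly that amino group: 1,3-dimethyl-1H-pyrazol-4-yl in place of hydrogen on a nitrogen on an aromatic ring. Among the compounds with values here, no measured step shows what happens when a ring is attached at this nitrogen; the one step that exists, from compound 1 to compound 2, only shows that this spot on the core responds strongly to change. Because of the size of a 19-fold higher number from compound 1 to compound 2 (1.27 log units; beyond the scatter) a clear shift in this assay is expected, and with the added ring the number is estimated to come down again rather than rise further. For compound 3 the estimate in this assay is 2 nM, between 0.4 nM and 10 nM, which amounts to a 6.5-fold lower number from compound 2 to compound 3 (0.81 log units; beyond the scatter) as an expected step.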

Compound 3, inhibition constant: 2 nM
Beside the measured number, compound 3's estimate shows no gap at the digits printed; the range from low to high includes it.
By their numbers in this assay, from the lowest: compound 1; then compound 3; then compound 2.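

In this assay, the nitrogen of the added amino group accepts a much larger substituent: 1,3-dimethyl-1H-pyrazol-4-yl in place of hydrogen on that nitrogen gives a 6.5-fold lower number from compound 2 to compound 3 (0.81 log units; beyond the scatter), so the earlier loss of a 19-fold higher number from compound 1 to compound 2 (1.27 log units; beyond the scatter) is not a fixed cost of having a nitrogen on this aromatic carbon. Set against the core with only hydrogen at this carbon, the whole (1,3-dimethyl-1H-pyrazol-4-yl)amino group still leaves a 2.9-fold higher number from compound 1 to compound 3 (0.46 log units; beyond the scatter), which means that much of the earlier loss is recovered, but not all of it. Nothing available here explains why the ring lowers the number.

The compounds shown leave open whether the lower number needs this particular ring or would follow from almost any group on this nitrogen, a question that a small methyl group or a plain phenyl ring in the same place could help to settle. Going by these compounds, it also remains open what the two methyl groups on the pyrazole contribute, a point that an unsubstituted pyrazol-4-yl ring would address directly.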